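This account rests on a few compounds, and the source may have more. Where it says the series, first, only, none or still open, it means among the compounds named here.

Measured in a functional assay on the whole organism for inhibition, with Rattus norvegicus as the target; a lower number here means that less compound is needed, a higher number that more compound is needed for the effect:
- compound 1 `O=C1N(CCN2CCC(c3cn(-c4ccc(F)cc4)c4ccc(Cl)cc34)CC2)CCN1c1ccccc1`: > 0.15 umol/kg (a limit, not a number)
- compound 2 `O=C1NCCN1CCCN1CCC(c2cn(-c3ccc(F)cc3)c3ccc(Cl)cc23)CC1`: 1.8 umol/kg

Among the measured compounds shown here, compound 2, at 1.8 umol/kg, holds the only true number so far, so it cannot yet be ranked against anything. The next compound is compound 3 `O=C1NCCN1CCCCCCN1CCC(c2cn(-c3ccc(F)cc3)c3ccc(Cl)cc23)CC1`, which differs from compound 2 as follows: 3-(2-oxoimidazolidin-1-yl)propyl in place of 2-oxoimidazolidin-1-yl on a saturated chain carbon, three bonds along the chain from an amine nitrogen in a ring. In words, 3-(2-oxoimidazolidin-1-yl)propyl stands in place of 2-oxoimidazolidin-1-yl, on a saturated chain carbon, three bonds along the chain from an amine nitrogen in a ring.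

For the measured compounds named here, the one measured step is a step that the limit leaves unreadable from compound 1 to compound 2. It is a different change, (2-oxoimidazolidin-1-yl)methyl in place of 2-oxo-3-phenylimidazolidin-1-yl, and it gives no size to carry over. Going by the values given here, no measured step therefore bears on this change in this assay, and the expectation rests on the value of compound 2 at 1.8 umol/kg. The expected step, with no firm direction and nothing beyond the scatter, is a 1.7-fold higher number from compound 2 to compound 3 (0.22 log units; within the scatter). For compound 3 the estimated value is 3 umol/kg, with an expected range from 0.7 umol/kg to 12 umol/kg.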

Compound 3, dose for half-maximal effect: > 2.2 umol/kg
Compound 3 gave a limit, no number; the forecaster's own chance of this, stated with the estimate: 25%; the middle value does not contradict the limit.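

In this assay, lengthening the chain at this position, with the 2-oxoimidazolidin-1-yl end kept, reads as an at least 1.2-fold higher number from compound 2 to compound 3 (0.08 log units; that floor lies within the scatter). Compound 3 carries a limit, not a number: the limit of > 2.2 umol/kg in this assay, at which 1 of the 3 values shown sits.

Among the compounds shown here, the floor therefore does not separate compound 3 from compound 2, while a much higher number for compound 3 remains open, so this is the first reading on chain length at this position, though only a one-sided one.

On these data alone, the steps from compound 1 cannot be read, so the phenyl group on the 2-oxoimidazolidin-1-yl ring cannot be weighed against the unsubstituted ring, and the true size of the chain effect stays unknown. Also open, as far as these compounds go, are chain lengths between those of compound 2 and compound 3, and chains that end in an amine or a carboxylic acid in place of the 2-oxoimidazolidin-1-yl ring.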